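Replacing the aryl group of compound 2: an expectation

The source may report more compounds than this note shows. Statements on the series, on what has been measured and on what is new or still open speak of the compounds shown alone.

Compound 1, `CCCCCCCCCCCCCCCCCCNC(=O)[C@H]1CSC(CCCCCCCCCCCC)N1`: in a functional assay on TSU-Pr1 cells for antiproliferative activity against TSU (Homo sapiens), read by sulforhodamine B assay (a higher number here means a weaker inhibitor, a lower number a stronger inhibitor), compound 1 gives 10700 nM.
Compound 2, `CCCCCCCCCCCCCCCCCCNC(=O)[C@H]1CSC(c2cc(F)cc(F)c2)N1`: in this assay compound 2 gives > 20000 nM.

Compound 2 carries a 3,5-difluorophenyl group on a saturated ring carbon where compound 1 carries a dodecyl chain. In this assay compound 2 reaches only a limit of the assay, > 20000 nM, so no number is known for it, as the limit of > 20000 nM in this assay, at which 1 of the 2 values shown sits, records. For the measured compounds named here, compound 1 is the only compound with a measured number, 10700 nM. Going by the values given here, the single measured step, an at least 1.8-fold higher number from compound 1 to compound 2 (0.27 log units; that floor lies within the scatter), is itself only a floor.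

Compound 3, `CCCCCCCCCCCCCCCCCCNC(=O)[C@H]1CSC(c2ccc(F)c(Br)c2)N1`, differs from compound 2 by 3-bromo-4-fluorophenyl in place of 3,5-difluorophenyl on a saturated ring carbon. Among the compounds with values here, no measured step exchanges one aromatic ring for another, so the only step that bears on it, an at least 1.8-fold higher number from compound 1 to compound 2 (0.27 log units; that floor lies within the scatter), tells merely that the aromatic replacement in compound 2 gave a weaker result than the chain in compound 1. With both compounds aromatic at this position, compound 3 is expected to land close to compound 2 in this assay, with a step that the limit leaves unreadable from compound 2 to compound 3 expected and a fair chance of another limit. Compound 3 is therefore estimated at 22000 nM, ranging from 8000 nM to 60000 nM.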

Compound 3, half-maximal inhibitory concentration: 14000 nM
Compound 3: the middle estimate sits 1.6-fold (0.20 log units) above what was measured, and the stated range covers the measured number.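

At this position an aromatic ring does not by itself carry a compound out of the measurable range of this assay: 3-bromo-4-fluorophenyl in place of dodecyl gives a 1.3-fold higher number from compound 1 to compound 3 (0.12 log units; within the scatter), so this ring and the chain read alike here. The only ring-for-ring change shown, 3-bromo-4-fluorophenyl in place of 3,5-difluorophenyl, gives an at least 1.4-fold lower number from compound 2 to compound 3 (0.15 log units; that floor lies within the scatter), so the two halogen patterns cannot yet be told apart. That step remains only a floor, since compound 2 sits at a limit of the assay: the limit of > 20000 nM in this assay, at which 1 of the 3 values shown sits.

The compounds shown leave open how far apart compound 2 and compound 3 really lie, and how a plain phenyl ring, or a phenyl ring carrying an amine or a carboxylic acid, would read at this position. They also leave open whether a chain shorter or longer than dodecyl would give a number that differs from that of compound 1 by more than the scatter.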